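Notes on compound 4, an amine-extended analogue of compound 2

A few compounds are considered here, and "the series" means these few. Any claim that something is new, unique, unknown or untested is made for them only; others in the source may bear on it.

Measured so far in an assay on HEK293 cells for displacement of a labelled ligand from Melanocortin receptor 4 (Homo sapiens); a lower number here means a stronger inhibitor, a higher number a weaker inhibitor:
compound 1, `CCCCC(N)c1cc(C(F)(F)F)ccc1N1CCN(C(=O)CCc2ccc(Cl)cc2Cl)CC1`: 190 nM
compound 2, `CC[C@H](C)C(N)c1cc(C(F)(F)F)ccc1N1CCN(C(=O)CCc2ccc(Cl)cc2Cl)CC1`: 75 nM
compound 3, `NC(COCc1ccccc1)c1cc(F)ccc1N1CCN(C(=O)CCc2ccc(Cl)cc2Cl)CC1`: 1000 nM

Compound 2 gives the lowest number of the three; the step of a 2.5-fold lower number from compound 1 to compound 2 (0.40 log units; beyond the scatter) is modest but beyond the scatter, and compound 3 stands further away, its value 1000 nM being well above that of compound 2.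

Compound 4, `CCC(C)CN[C@H](c1cc(C(F)(F)F)ccc1N1CCN(C(=O)CCc2ccc(Cl)cc2Cl)CC1)C(C)CC`, differs from compound 2 by 2-methyl-1-((2-methylbutyl)amino)butyl in place of 1-amino-2-methylbutyl on an aromatic carbon. Among the compounds with values here, the only single-point step measured, a 2.5-fold lower number from compound 1 to compound 2 (0.40 log units; beyond the scatter), alters the saturated chain and leaves the amine untouched, so it does not bear directly on this change. Within the data shown here, no measured pair supports a direction; the step of a 2.0-fold higher number from compound 2 to compound 4 (0.30 log units; within the scatter) is therefore expected to stay near the scatter, with the range kept wide. Compound 4 is estimated at 150 nM, between 40 nM and 600 nM.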

Compound 4, inhibition constant: 2800 nM
For compound 4 the middle estimate is 19-fold (1.27 log units) below the measured one, outside the stated range (above it).
By their numbers in this assay, from the lowest: compound 2; then compound 1; then compound 3; then compound 4.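

In (this assay), 2-methyl-1-((2-methylbutyl)amino)butyl in place of 1-amino-2-methylbutyl on this aromatic carbon costs far more (a 37-fold higher number from compound 2 to compound 4 (1.57 log units; beyond the scatter)) than the change in the saturated chain did (a 2.5-fold lower number from compound 1 to compound 2 (0.40 log units; beyond the scatter)). Set against the 1-aminopentyl group, the same substituent also gives a large rise (a 15-fold higher number from compound 1 to compound 4 (1.17 log units; beyond the scatter)), so in these pairs the added 2-methylbutyl on the amine nitrogen outweighs the choice of chain. No evidence on hand accounts for this rise.

As far as these compounds go, whether a smaller group on that nitrogen, such as methyl or ethyl, would keep the number of compound 2 remains open.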